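The compounds below may be only part of what the source reports. "The series", "measured", "known", "first", "only" and "open" are said of these compounds alone.

Measured in a functional assay on MCF7 cells (Homo sapiens) for antiproliferative activity, read by MTT assay, with a stated time of 48 h; a lower number here means a stronger inhibitor, a higher number a weaker inhibitor:
- Compound 1 `COc1cc(C2=N/C(=C\c3cc(Br)cc(Br)c3OC(C)=O)C(=O)NN2C(N)=S)cc(OC)c1OC`: 360 nM
- Compound 2 `CC(=O)Oc1c(Br)cc(Br)cc1/C=C1\N=C(c2ccccc2)N(c2ncc(-c3ccccc3)s2)NC1=O`: 38300 nM
- Compound 3 `COc1ccc(C2=N/C(=C\c3cc(Br)cc(Br)c3OC(C)=O)C(=O)NN2c2ncc(-c3ccccc3)s2)cc1OC`: 4330 nM

Compound 3 holds the middle place of these three numbers, lower than compound 2 and higher than compound 1. Compound 4 `COc1cc(C2=N/C(=C\c3cc(Br)cc(Br)c3OC(C)=O)C(=O)NN2c2ncc(-c3ccccc3)s2)cc(OC)c1OC` differs from compound 3 by one change, 3,4-dimethoxyphenyl to 3,4,5-trimethoxyphenyl: methoxy in place of hydrogen on an aromatic carbon. For the measured compounds named here, one measured step bears on this, the 3,4-dimethoxyphenyl in place of phenyl, which gave an 8.8-fold lower number from compound 2 to compound 3 (0.95 log units; beyond the scatter). A single further methoxy in place of hydrogen is expected to act in the same direction but by less, towards a lower number in this assay. The estimated step is a 2.5-fold lower number from compound 3 to compound 4 (0.41 log units; beyond the scatter). The expected value for compound 4 is 1700 nM, within an estimated range of 400 nM to 5500 nM.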

Compound 4, half-maximal inhibitory concentration: 410 nM
The estimate for compound 4 lay 4.1-fold (0.62 log units) above the measured number, and the stated range covers the measured number.
By their numbers in this assay, from the lowest: compounds 1 and 4 (each within the scatter of the next); then compound 3; then compound 2.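

In this assay, a single methoxy in place of hydrogen on this aromatic carbon is a large step by itself, an 11-fold lower number from compound 3 to compound 4 (1.02 log units; beyond the scatter), and the full 3,4,5-trimethoxyphenyl in place of phenyl gives a 93-fold lower number from compound 2 to compound 4 (1.97 log units; beyond the scatter). With that group present, the two groups on the amine nitrogen in the ring read alike, a 1.1-fold higher number from compound 1 to compound 4 (0.06 log units; within the scatter). Nothing available explains these steps. From the compounds shown here alone, it remains open whether a hydroxy, ethoxy or fluorine at this place would act like methoxy, and whether the step holds with other groups on that nitrogen.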